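This account rests on a few compounds, and the source may have more. Where it says the series, first, only, none or still open, it means among the compounds named here.

In an ADME assay on microsomes from liver (Rattus norvegicus) for metabolic stability, read by LC-MS, using NADPH, with a stated time of 30 min, tested at 0.1 uM (on this read-out higher numbers stand for a more stable compound and lower numbers for a less stable compound), compound 1 `O=S(=O)(NCC1COC1)c1cccc(-c2ccc3nccc(-c4ccncc4)c3n2)c1` gives 8%. Going by the values given here, compound 2 `O=S(=O)(NCCN1CCCC1)c1cccc(-c2ccc3nccc(-c4ccnc(C(F)(F)F)c4)c3n2)c1`, the only other compound measured so far, gives 16%. These two numbers lie within the usual scatter of each other, so compound 1 stands level with compound 2. Compound 3 `O=S(=O)(c1cccc(-c2ccc3nccc(-c4ccncc4)c3n2)c1)N1CCC(O)CC1` keeps the core of compound 1 and differs in one group: 4-hydroxypiperidin-1-yl in place of ((oxetan-3-yl)methyl)amino on a sulfonyl sulfur. In words, 4-hydroxypiperidin-1-yl takes the place of ((oxetan-3-yl)methyl)amino on a sulfonyl sulfur, and neither group carries a net charge. Among the compounds with values here, no measured pair shows what a change of this kind does, so the data offer no direct guide. The expectation in this assay is therefore for no step beyond the scatter. The estimated change is a number 6 percentage points higher from compound 1 to compound 3 (within the scatter). Compound 3 is expected to give 14%, with an estimated range from 4% to 32%.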

Compound 3, percent of the compound remaining: 11%
The estimate for compound 3 lay 3 percentage points above the measured number; the measured number falls inside the stated range.
By their numbers in this assay, from the lowest: compounds 1, 3 and 2 (each within the scatter of the next).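

Placing 4-hydroxypiperidin-1-yl in place of ((oxetan-3-yl)methyl)amino on a sulfonyl sulfur gives the first step that can be read at this position in this assay, and it is a number 3 percentage points higher from compound 1 to compound 3 (within the scatter). A six-membered non-aromatic ring can thus stand where a four-membered one stood, with no net charge on either group, without a change beyond the usual scatter of this read-out. Nothing available here explains this result. Still open, on these data alone, is whether a group of another kind on this sulfonyl sulfur, such as a carboxylic acid or a morpholine ring, would give a step beyond the scatter. Compound 2 differs from compound 1 in more than one place, so it cannot settle this question.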